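Acetylated diol series: three limits, one open position

A few compounds are considered here, and "the series" means these few. Any claim that something is new, unique, unknown or untested is made for them only; others in the source may bear on it.

Compound 1 `COc1nc(CC(O)(COC(C)=O)COC(C)=O)c(C)c(OC)n1` in a functional assay on HeLa cells (Homo sapiens) for antiproliferative activity, read by MTT assay, with a stated time of 72 h (a lower number here means a stronger inhibitor, a higher number a weaker inhibitor), gives > 100000 nM, which is a limit of the assay.
Compound 2 `COc1nc(CC(F)(COC(C)=O)COC(C)=O)c(C)c(OC)n1` in this assay gives > 100000 nM, also a limit.
Compound 3 `COc1nc(=O)n(C)c(CC(F)(COC(C)=O)COC(C)=O)c1C` in this assay gives > 100000 nM, again a limit.

Going by the values given here, every measured value so far sits at the limit of > 100000 nM in this assay, at which 3 of the 3 values shown sit. Compound 2 and compound 1 differ by hydroxy in place of fluoro on a saturated chain carbon bound to three saturated chain carbons, and the step that the two limits leave unreadable from compound 2 to compound 1 cannot be read, as both ends are limits. Compound 3 and compound 2 are built from the same atoms joined differently; the difference between the two cores is not broken down here. Compound 4 `COc1nc(=O)n(C)c(CC(O)(COC(C)=O)COC(C)=O)c1C` relates to compound 3 by the same change, (hydroxy in place of fluoro on a saturated chain carbon bound to three saturated chain carbons), at the same place. For compound 4 the expected step that the limit leaves unreadable from compound 3 to compound 4 is small, resting on compound 2 and compound 1 both sitting at the limit of > 100000 nM in this assay, at which 3 of the 3 values shown sit. Compound 4 is therefore estimated at 200000 nM, between 100000 nM and 500000 nM, and most likely reported only as a limit.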

Compound 4, half-maximal inhibitory concentration: > 100000 nM
Compound 4: only a limit was reported; the forecaster's own chance of this, stated with the estimate: 90%; the middle value is on the limit's open side.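

Compound 3 and compound 4 are both limits, so no step between them can be read: the limit of > 100000 nM in this assay, at which 4 of the 4 values shown sit.

The compounds shown leave open how hydroxy and fluoro compare on a saturated chain carbon bound to three saturated chain carbons, on either core.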